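The compounds below may be only part of what the source reports. "The series", "measured", "known", "first", "only" and "open" are said of these compounds alone.

For the measured compounds named here, in an in vivo functional assay on the whole organism for inhibition, with Rattus norvegicus as the target (a lower number here means that less compound is needed, a higher number that more compound is needed for the effect), three compounds with a shared core have numbers so far. Compound 1 `CCCCc1nc(C)c(CC(=O)O)c(=O)n1Cc1ccc(-c2ccccc2-c2nnn[nH]2)cc1`, with hydroxy on the carbonyl carbon, gives 0.13 mg/kg. Compound 2 `CCCCc1nc(C)c(CC(=O)N(CC)CC)c(=O)n1Cc1ccc(-c2ccccc2-c2nnn[nH]2)cc1`, with diethylamino there, gives 0.089 mg/kg, and the change is a 1.5-fold lower number from compound 1 to compound 2 (0.16 log units; within the scatter). Compound 3 `CCCCc1nc(C)c(CC(=O)N2CC(C)OC(C)C2)c(=O)n1Cc1ccc(-c2ccccc2-c2nnn[nH]2)cc1`, with 2,6-dimethylmorpholin-4-yl in that place, gives 0.029 mg/kg, the lowest of the three numbers. It stands apart from both others, with a 4.5-fold lower number from compound 1 to compound 3 (0.65 log units; beyond the scatter) and a 3.1-fold lower number from compound 2 to compound 3 (0.49 log units; beyond the scatter).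

The next compound, compound 4 `CCCCc1nc(C)c(CCC(=O)N2CCC[C@H]2C(=O)OC)c(=O)n1Cc1ccc(-c2ccccc2-c2nnn[nH]2)cc1`, has not yet been measured. Its difference from compound 3 is this: ((2-(methoxycarbonyl)pyrrolidin-1-yl)carbonyl)methyl in place of (2,6-dimethylmorpholin-4-yl)carbonyl on a saturated chain carbon bound to an aromatic carbon. The entering group also carries a defined stereocentre.

The measured steps bear on this change only in part. Going by the values given here, all three exchange the group on a carbonyl carbon, and none alters the chain that carries it, so the data offer no direct precedent for the added methyl unit or for the 2-(methoxycarbonyl)pyrrolidin-1-yl group. The largest of them, a 4.5-fold lower number from compound 1 to compound 3 (0.65 log units; beyond the scatter), sets a modest scale. Compound 3 holds the lowest number, so a move back toward compound 2 at 0.089 mg/kg seems the likelier direction. The expected step is a 2.8-fold higher number from compound 3 to compound 4 (0.44 log units; beyond the scatter), with wide uncertainty. For compound 4 the estimated value is 0.08 mg/kg, with an expected range from 0.02 mg/kg to 0.3 mg/kg.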

Compound 4, dose for half-maximal effect: 0.063 mg/kg
For compound 4 the middle estimate is 1.3-fold (0.10 log units) above the measured one; low and high end bracket the measured number.
By their numbers in this assay, from the lowest: compound 3; then compounds 4, 2 and 1 (each within the scatter of the next, the first and the last beyond it).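

In this assay, for the compounds shown here, the ((2-(methoxycarbonyl)pyrrolidin-1-yl)carbonyl)methyl group shows that this saturated chain carbon bound to an aromatic carbon can carry a different chain and a larger group with a defined stereocentre while the number stays inside the range of the earlier compounds: it gives up some ground to the 2,6-dimethylmorpholin-4-yl amide (a 2.2-fold higher number from compound 3 to compound 4 (0.34 log units; beyond the scatter)), remains ahead of the free carboxy compound (a 2.1-fold lower number from compound 1 to compound 4 (0.31 log units; beyond the scatter)), and cannot be separated from the diethylcarbamoyl compound (a 1.4-fold lower number from compound 2 to compound 4 (0.15 log units; within the scatter)). The step from compound 3 alters the chain and the ring on the amide together, so the share of each in the result cannot be told apart. Nothing available accounts for these differences.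

The compounds shown leave open how the 2-(methoxycarbonyl)pyrrolidin-1-yl amide behaves on the shorter chain of compound 3, and how the 2,6-dimethylmorpholin-4-yl amide behaves on the longer chain of compound 4. They also leave open what the opposite stereocentre, or a free carboxylic acid in place of the methyl ester on the pyrrolidine, would give.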